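Aryl swap on the saturated ring carbon of compound 1

The source may report more compounds than this note shows. Statements on the series, on what has been measured and on what is new or still open speak of the compounds shown alone.

Compound 1 `O=C(Nc1cc2cc[nH]c(=O)c2cc1Cl)C1CNCC1c1ccccn1`: in an assay on isolated protein for inhibition of Rho-associated protein kinase 2 (Homo sapiens), read by a luciferase reporter (a higher number here means a weaker inhibitor, a lower number a stronger inhibitor), compound 1 gives 14 nM.
Compound 2 `O=C(Nc1cc2cc[nH]c(=O)c2cc1Cl)C1CNCCC1c1ccccc1`: in this assay compound 2 gives 6 nM.

Among the measured compounds shown here, compound 1 holds the higher of the two numbers; compound 2 gives the lower one, a gap beyond the scatter, but the two differ in more than one place, so no single step is read from them. Compound 3 `Cc1cccc(C2CNCC2C(=O)Nc2cc3cc[nH]c(=O)c3cc2Cl)c1` keeps the core of compound 1 and carries 3-methylphenyl in place of pyridin-2-yl on a saturated ring carbon. For the measured compounds named here, no measured step bears on this change. For compound 3 a shift no larger than the scatter is expected, in either direction, a 1.1-fold higher number from compound 1 to compound 3 (0.03 log units; within the scatter). Compound 3 is expected at 15 nM, within 5 nM to 45 nM.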

Compound 3, half-maximal inhibitory concentration: 5 nM
The estimate for compound 3 lay 3.0-fold (0.48 log units) above the measured number; low and high end bracket the measured number.
By their numbers in this assay, from the lowest: compounds 3 and 2 (each within the scatter of the next); then compound 1.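

Among the compounds shown here, on the saturated ring carbon, 3-methylphenyl in place of pyridin-2-yl gives a 2.8-fold lower number from compound 1 to compound 3 (0.45 log units; beyond the scatter) in this assay, the first single-place step. This position therefore responds to a change of aryl group, and the ring nitrogen of pyridin-2-yl is not needed for a value as low as that of compound 3. No available data explain the step.

Still open, as far as these compounds go, is how far the methyl and the carbon-only ring each contribute to this step. An unsubstituted phenyl on this five-membered ring would separate the two, and a methoxy or chloro group in place of the methyl would show how much this substituent can vary.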